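Swapping Trifluoromethyl for Cyclobutyl on an Ether Chain

A few compounds are considered here, and "the series" means these few. Any claim that something is new, unique, unknown or untested is made for them only; others in the source may bear on it.

Compound 1 `CC1(CS(C)(=O)=O)CN(c2cc(COc3ccc(F)c(F)c3F)nc(-c3ccccn3)n2)C1` carries a 3-methyl-3-((methylsulfonyl)methyl)azetidin-1-yl group on the shared core. In a functional assay on cells for antagonist activity at Free fatty acid receptor 1 (Homo sapiens), read by TR-FRET and inositol phosphate accumulation, with a stated time of 2 h (on this read-out higher numbers stand for weaker inhibition and lower numbers for stronger inhibition), compound 1 gives 6310 nM. Compound 2 `CC1(C#N)CN(c2cc(COc3ccc(F)c(F)c3F)nc(-c3ccccn3)n2)C1` has cyano in place of (methylsulfonyl)methyl on a saturated ring carbon; in this assay compound 2 gives 158 nM, which is a 40-fold lower number from compound 1 to compound 2 (1.60 log units; beyond the scatter). Compound 3 `Fc1ccc(OCc2cc(OCC(F)(F)F)nc(-c3ccccn3)n2)c(F)c1F` instead carries a 2,2,2-trifluoroethoxy group on that aromatic carbon; in this assay compound 3 gives 7.94 nM. That is a 20-fold lower number from compound 2 to compound 3 (1.30 log units; beyond the scatter) and a 790-fold lower number from compound 1 to compound 3 (2.90 log units; beyond the scatter). Compound 3 thus stands lowest of the three, with both steps towards it beyond the scatter.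

Compound 4 `Fc1ccc(OCc2cc(OCC3CCC3)nc(-c3ccccn3)n2)c(F)c1F` differs from compound 3 by cyclobutyl in place of trifluoromethyl on a saturated chain carbon bound to an oxygen on an aromatic ring. None of the three measured steps touches this chain: each of them changes the group on the aromatic carbon of the core, not what sits beyond the ether oxygen. The data therefore give no guide to the size or direction of this step. Starting from compound 3, which gives 7.94 nM, a change that stays near the scatter is expected, and the estimate for compound 4 in this assay is 15 nM, with a range from 4 nM to 60 nM. This corresponds to an expected step of a 1.9-fold higher number from compound 3 to compound 4 (0.28 log units; within the scatter).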

Compound 4, half-maximal inhibitory concentration: 12.6 nM
Beside the measured number, compound 4's estimate is 1.2-fold (0.08 log units) above it; measured number inside the range.
By their numbers in this assay, from the lowest: compounds 3 and 4 (each within the scatter of the next); then compound 2; then compound 1.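

At this position, on a saturated chain carbon bound to an oxygen on an aromatic ring, the all-carbon cyclobutyl ring takes the place of trifluoromethyl with no change beyond the usual scatter in this assay (a 1.6-fold higher number from compound 3 to compound 4 (0.20 log units; within the scatter)), so the fluorine atoms of the chain end are not required for a low number on this read-out. The large gap to the azetidine compounds also survives the swap (a 13-fold lower number from compound 2 to compound 4 (1.10 log units; beyond the scatter); a 500-fold lower number from compound 1 to compound 4 (2.70 log units; beyond the scatter)), which shows that this gap does not belong to 2,2,2-trifluoroethoxy alone, since cyclobutylmethoxy shows it as well. Nothing measured here says why trifluoromethyl and cyclobutyl read so much alike in this assay.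

As far as these compounds go, with only these two chain ends on show, it remains open how much this position tolerates, for instance whether a cyclohexyl ring, a longer alkyl chain, or a chain ending in an amine or a carboxylic acid would keep the number this low. From the compounds shown here alone, it is also open whether a plain methyl at the same place would do as well, which would tell whether the chain end needs any bulk at all.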